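The source may report more compounds than this note shows. Statements on the series, on what has been measured and on what is new or still open speak of the compounds shown alone.

Compound 1, `COc1cc(O)cc(O)c1C(=O)/C=C/c1ccco1`: 384000 nM in a toxicity assay on cells (Macrophage, Mus musculus, strain BALB/c) for cytotoxicity, read by MTT assay; on this read-out higher numbers stand for weaker inhibition and lower numbers for stronger inhibition
Compound 2, `COc1cc(O)cc(O)c1C(=O)/C=C/c1ccc(Cl)cc1`: 19000 nM in this assay
Compound 3, `C=CCOc1cc(OC)c(C(=O)/C=C/c2cccc(OC)c2)c(OCC=C)c1`: 13100 nM in this assay

Among the three numbers, compound 2 gives the second highest. Compound 3 stands nearest to it, within the scatter, so the two cannot be ordered. Among the compounds with values here, compound 1 lies furthest away, and that gap is the only step between compounds that differ in one place: a 20-fold lower number from compound 1 to compound 2 (1.31 log units; beyond the scatter).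

Compound 4, `COc1cc(O)cc(O)c1C(=O)/C=C/c1ccc(O)cc1`, has not yet been measured in this assay. It differs from compound 2 at one place: hydroxy in place of chloro on an aromatic carbon. Within the data shown here, no measured step covers this exchange. Among the measured compounds shown here, the one step on record, a 20-fold lower number from compound 1 to compound 2 (1.31 log units; beyond the scatter), swaps the entire group at the end of the chain and shows that this end can move the number a long way, but it says nothing about trading one substituent for another on the same group. The step is therefore expected to be modest, a 2.4-fold higher number from compound 2 to compound 4 (0.37 log units; beyond the scatter), toward a higher number. Compound 4 is expected to give about 45000 nM, within a range from 15000 nM to 150000 nM.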

Compound 4, half-maximal inhibitory concentration: 21700 nM
The estimate for compound 4 lay 2.1-fold (0.32 log units) above the measured number; low and high end bracket the measured number.
By their numbers in this assay, from the lowest: compounds 3, 2 and 4 (each within the scatter of the next); then compound 1.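

Trading chloro for hydroxy on an aromatic carbon para to a large group leaves the number in this assay unresolved from that of the parent (a 1.1-fold higher number from compound 2 to compound 4 (0.06 log units; within the scatter)), even though the entering group counts a hydrogen-bond donor and a hydrogen-bond acceptor and the leaving one counts neither. The large distance from the furan-2-yl compound also holds with the new end group (an 18-fold lower number from compound 1 to compound 4 (1.25 log units; beyond the scatter)), so both 4-substituted phenyl compounds, and not only the 4-chlorophenyl one, stand far from compound 1. No measurement at hand accounts for either result.

Going by these compounds, whether this position stays as indifferent with larger or charged groups, such as a dimethylamino group or a carboxylic acid, remains open. Also open, on these data alone, is how a phenyl ring with no substituent at all would compare.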